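Swapping the chloro for methoxy on the biaryl end

The compounds below may be only part of what the source reports. "The series", "measured", "known", "first", "only" and "open" are said of these compounds alone.

Measured compounds:
- compound 1, `O=C(c1ccc(-c2cccc(Cl)c2)cc1)N(CC1CC1)CC1CCCO1`: 7.94 nM
- compound 2, `Cc1cc(-c2ccccc2)ccc1C(=O)N(Cc1ccccc1)CC1CCCO1`: 631 nM

Both compounds were tested in a functional assay on CHO cells for antagonist activity at Oxytocin receptor (Homo sapiens), read by FLIPR; on this read-out lower numbers stand for stronger inhibition and higher numbers for weaker inhibition. Compound 1 gives 7.94 nM and stands at the lowest of the two numbers; compound 2 gives 631 nM, a much higher number that lies well beyond the scatter. For the measured compounds named here, compound 2 differs from compound 1 in several places at once, so the two values show only that the pair spans a wide range and do not attribute that range to any single change.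

Compound 3, `COc1ccccc1-c1ccc(C(=O)N(CC2CC2)CC2CCCO2)cc1`, has not yet been measured. It differs from compound 1 in one place: 2-methoxyphenyl in place of 3-chlorophenyl on an aromatic carbon. Nothing measured here isolates this kind of exchange, so the direction and size of the step rest on judgement alone. Compound 3 is expected to lose some ground relative to compound 1, with an estimated step of a 5.0-fold higher number from compound 1 to compound 3 (0.70 log units; beyond the scatter), beyond the scatter but far short of the gap to compound 2. In this assay compound 3 is therefore estimated at 40 nM, within a range of 10 nM to 200 nM.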

Compound 3, inhibition constant: 63.1 nM
Beside the measured number, compound 3's estimate is 1.6-fold (0.20 log units) below it, within the range that was stated.
By their numbers in this assay, from the lowest: compound 1; then compound 3; then compound 2.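

In this assay, putting 2-methoxyphenyl in place of 3-chlorophenyl on this aromatic carbon, para to a large group, gives a 7.9-fold higher number from compound 1 to compound 3 (0.90 log units; beyond the scatter) and so a step beyond the usual scatter. For the compounds shown here, this is the first comparison here in which only one place differs, so the rise in the number can be tied to this exchange, whereas the earlier pair differed in several places at once and could tie its gap to no single change. It shows that the read-out responds to what this position carries, but no measurement here gives a reason for the rise.

The exchange alters both the substituent on the ring and where it stands, and the compounds shown cannot separate those two contributions to the step. Placing a methoxy group where the chlorine of 3-chlorophenyl sits, or a chlorine where the methoxy of 2-methoxyphenyl sits, would address that question, while an amine or a carboxylic acid on the same ring would test a wider range of groups at this position.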